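The compounds below may be only part of what the source reports. "The series", "measured", "known", "first", "only" and "open" are said of these compounds alone.

Measured compounds:
Compound 1 `CC(=O)Nc1ccc(-n2nncc2CN2C(=O)C3(C(C#N)=C(N)Oc4c3c3nc5ccccc5nc3c3ccccc43)c3ccccc32)cc1` — in a functional assay on MCF7 cells (Homo sapiens) for antiproliferative activity, read by MTT assay, with a stated time of 48 h (a lower number here means a stronger inhibitor, a higher number a weaker inhibitor), compound 1 gives > 50000 nM, which is a limit of the assay rather than a number.
Compound 2 `N#CC1=C(N)Oc2c(c3nc4ccccc4nc3c3ccccc23)C12C(=O)N(Cc1cnnn1-c1ccc(Cl)c(Cl)c1)c1ccccc12` — in this assay compound 2 gives > 50000 nM, also a limit.
Compound 3 `Cc1ccccc1-n1nncc1CN1C(=O)C2(C(C#N)=C(N)Oc3c(N)cc4nc5ccccc5nc4c32)c2ccccc21` — in this assay compound 3 gives > 50000 nM, again a limit.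

Compound 3 therefore stands at the same place as the other two: no number is known for it, only the limit, and the same holds for the two further values shown, as summed up in the limit of > 50000 nM in this assay, at which 3 of the 3 values shown sit. Compound 4 `N#CC1=C(N)Oc2c(N)cc3nc4ccccc4nc3c2C12C(=O)N(Cc1cnnn1-c1cccc(C(F)(F)F)c1)c1ccccc12` differs from compound 3 in one place: 3-(trifluoromethyl)phenyl in place of 2-methylphenyl on an aromatic nitrogen. Among the compounds with values here, the only measured step between neighbours, a step that the two limits leave unreadable from compound 1 to compound 2, runs between two limits and its size cannot be read, so nothing measured bears on the size or direction of the step from compound 3 to compound 4. No step beyond the scatter is expected in this assay; the estimated step that the limit leaves unreadable from compound 3 to compound 4 is accordingly flat, and compound 4 is expected to sit again at the limit. The estimate for compound 4 is 60000 nM, within 20000 nM to 200000 nM.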

Compound 4, half-maximal inhibitory concentration: 31600 nM
Beside the measured number, compound 4's estimate is 1.9-fold (0.28 log units) above it, and the stated range covers the measured number.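

Within the data shown here, compound 4 is the first compound to give a number rather than a limit in this assay, so a change on this aromatic nitrogen of the five-membered ring can bring a value into readable range. The exchange of 2-methylphenyl for 3-(trifluoromethyl)phenyl gives an at least 1.5-fold lower number from compound 3 to compound 4 (0.19 log units; that floor lies within the scatter), so the compounds do not establish a step beyond the scatter, and the other steps between neighbours cannot be read. Compound 4 stands alone in this respect: the limit of > 50000 nM in this assay, at which 3 of the 4 values shown sit.

The change alters both the group on the phenyl ring and where that group sits, and the compounds shown do not separate the two. On these data alone, whether an amine or a carboxylic acid in place of the trifluoromethyl group would also give a number in this assay stays open.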